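Swapping a Sulfanyl Arm for Nitro on the Benzyl Ring

The source may hold more compounds than are shown below. What is called first, only, known or untested is meant among the compounds shown, and "the series" means these compounds.

Measured so far in an assay on CHO cells for antagonist activity at transient receptor potential cation channel subfamily V member 1 (Homo sapiens), read by FLIPR; on this read-out higher numbers stand for weaker inhibition and lower numbers for stronger inhibition:
compound 1, `CCCN(CCC)c1cc(C(F)(F)F)ccc1CNC(=O)C(C)c1ccc(NS(C)(=O)=O)c(F)c1`, gives 0.3 nM
compound 2, `CC(C(=O)NCc1ccc(C(F)(F)F)cc1SCc1ccco1)c1ccc(NS(C)(=O)=O)c(F)c1`, gives 3.2 nM

Going by the values given here, compound 2 has the highest of the two numbers, meaning it is the weaker inhibitor of the pair, and its only neighbour is compound 1, which has the lower number. Among the compounds with values here, the single measured step, an 11-fold higher number from compound 1 to compound 2 (1.03 log units; beyond the scatter), shows that exchanging the group at this position can move the number by a large amount.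

Compound 3, `CC(C(=O)NCc1ccc(C(F)(F)F)cc1[N+](=O)[O-])c1ccc(NS(C)(=O)=O)c(F)c1`, carries the change (nitro in place of ((furan-2-yl)methyl)sulfanyl on an aromatic carbon). Within the data shown here, that is a different kind of exchange from the one measured, and no step in this small set directly mirrors it; the one step, an 11-fold higher number from compound 1 to compound 2 (1.03 log units; beyond the scatter), only shows this position is sensitive to what is attached there. Nitro is a far smaller group with no ring. A modest rise of the number is expected, as the step of a 3.1-fold higher number from compound 2 to compound 3 (0.49 log units; beyond the scatter), with wide uncertainty. For compound 3 the estimate is 10 nM, with a range from 2 nM to 60 nM.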

Compound 3, inhibition constant: "not active" (no number reported)
Nothing numeric was reported for compound 3, and the estimate cannot be compared.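

Going by these compounds alone, compound 3 is reported as not active in this assay with no number given, so no step from compound 2 to compound 3 can be read. These compounds leave open how far nitro in place of ((furan-2-yl)methyl)sulfanyl shifts the number. No measurement shown here explains this result.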